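Moving a Bromine Around a Ring in a Folate Enzyme Series

The compounds below may be only part of what the source reports. "The series", "measured", "known", "first", "only" and "open" are said of these compounds alone.

The measurement used throughout is an assay on isolated protein for inhibition of Dihydrofolate reductase (Homo sapiens), read by spectrophotometry, using NADPH, with stated times of 5 s and 6 min, tested at 50 uM; a higher number here means a stronger effect of the compound at the concentration tested, a lower number a weaker effect. Among the measured compounds shown here, compound 1, `CC(C)(C)c1ccc(OCCCON2C(N)=NC(N)=NC23CCSCC3)cc1`, carries a tert-butyl group on the outer ring and gives the only number so far: in this assay compound 1 shows 86.6%, a strong effect at the single concentration tested. Compound 2, `NC1=NC2(CCSCC2)N(OCCCOc2ccc(Br)cc2)C(N)=N1`, keeps the same core and linker but has a 4-bromophenyl group in place of the tert-butyl-bearing ring; for compound 2 the entry in this assay reads "not determined" (no result reported), so it stands nowhere on the numbers shown and offers no anchor of its own. Compound 3, `NC1=NC2(CCSCC2)N(OCCCOc2cccc(Br)c2)C(N)=N1`, differs from compound 2 only in the position of the bromine: 3-bromophenyl in place of 4-bromophenyl on an oxygen on a saturated carbon. For the measured compounds named here, since no step between measured compounds is available, the expectation rests on compound 1 alone, whose value of 86.6% suggests that this scaffold is generally well tolerated in this assay. The rearrangement of the bromine is expected to change the read-out in this assay by no more than the usual scatter, in no particular direction. For compound 3, the inhibition in this assay is estimated at 80%, with a plausible range from 55% to 95%.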

Compound 3, a percentage reported as inhibition, at one concentration (the size of the read-out at that concentration, not a potency): 86.5%
Compound 3: middle estimate off by 6.5 percentage points, on the low side; measured number inside the range.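

Compound 2 has no number in this assay, so moving the bromine from 4-bromophenyl in compound 2 to 3-bromophenyl in compound 3 cannot be read as a step. What the compounds shown leave open is whether the position of the bromine on the ring changes the read-out at all. No supporting evidence bears on the result for compound 3.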